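The compounds below may be only part of what the source reports. "The series", "measured", "known", "first", "only" and "open" are said of these compounds alone.

Measured compounds:
- compound 1, `COc1nc2ccc(Br)cc2cc1C(c1ccccc1)n1cc(-c2ccccc2)nn1`, giving 30.1% in an ADME assay on PANC-1 cells (Homo sapiens) for cytotoxicity, read by sulforhodamine B assay, with a stated time of 48 h, tested at 10 uM; on this read-out lower numbers stand for less inhibition and higher numbers for more inhibition at the one concentration tested (going by the name of the read-out)
- compound 2, `CCOC(=O)c1cn(C(c2ccccc2)c2cc3cc(Br)ccc3nc2OC)nn1`, giving 15.4%
- compound 3, `CCCCCc1cn(C(c2ccccc2)c2cc3cc(Br)ccc3nc2OC)nn1`, giving 5.07%

Compound 3 stands lowest of the three numbers. Its nearest neighbour is compound 2, from which it is separated by a number 10.3 percentage points lower from compound 2 to compound 3 (beyond the scatter), and the widest gap is to compound 1, a number 25 percentage points lower from compound 1 to compound 3 (beyond the scatter). Both steps arrive at compound 3 through the pentyl group on the aromatic carbon, once in place of ethoxycarbonyl and once in place of phenyl.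

The unmeasured compound 4 is `CCCc1cn(C(c2ccccc2)c2cc3cc(Br)ccc3nc2OC)nn1`. Its difference from compound 3 is hydrogen in place of ethyl on a saturated chain carbon, three bonds along the chain from an aromatic carbon, which reads as pentyl to propyl: the chain on the aromatic carbon keeps its kind but becomes shorter.

Among the compounds with values here, none of the measured steps shortens a chain; each exchanges the whole group on that aromatic carbon for one of another kind. The steps of a number 25 percentage points lower from compound 1 to compound 3 (beyond the scatter) and a number 10.3 percentage points lower from compound 2 to compound 3 (beyond the scatter) therefore bear on compound 4 only loosely, by showing that the pentyl-bearing compound 3 gives the lowest number. Within the data shown here, with no directly comparable step, the expected change from compound 3 to compound 4 is small, a number 2.9 percentage points higher from compound 3 to compound 4 (within the scatter), within the scatter or a slight rise toward compound 2.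

Compound 4 is estimated at 8%, with a range from 0% to 20%.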

Compound 4, a percentage reported as inhibition, at one concentration (the size of the read-out at that concentration, not a potency): 11.3%
Compound 4: middle estimate off by 3.3 percentage points, on the low side; the measured number falls inside the stated range.
By their numbers in this assay, from the lowest: compounds 3, 4 and 2 (each within the scatter of the next, the first and the last beyond it); then compound 1.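

Shortening pentyl to propyl on the aromatic carbon gives a number 6.2 percentage points higher from compound 3 to compound 4 (within the scatter) in this assay, so this first change of chain length within a single kind of group does not move the number past the usual scatter. The propyl compound also shows a number 4.1 percentage points lower from compound 2 to compound 4 (within the scatter) and thus cannot be told apart from the ethoxycarbonyl compound, even though the pentyl compound could be, so the separation between ethoxycarbonyl and an alkyl chain holds for pentyl but not for propyl, while a number 18.8 percentage points lower from compound 1 to compound 4 (beyond the scatter) shows that phenyl stays apart from propyl as it did from pentyl. Nothing presented here gives a reason for these numbers.

As far as these compounds go, whether a methyl, a butyl or a chain longer than pentyl would stay in the same band remains open, as does whether the higher number of compound 1 carries over to other ring groups such as benzyl or pyridyl. Also open is where an amine or a carboxylic acid on that same aromatic carbon would fall in this assay, since the groups shown are limited to phenyl, ethoxycarbonyl and two straight chains.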